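This account rests on a few compounds, and the source may have more. Where it says the series, first, only, none or still open, it means among the compounds named here.

Measured so far in a functional assay on KB cells (Homo sapiens) for inhibition, read by MTT assay, with a stated time of 24 h, tested at 100 ug/mL; on this read-out lower numbers stand for less inhibition of growth and higher numbers for more inhibition of growth at the one concentration tested:
compound 1 `O=C(CCCCC1CCSS1)Nc1ccccn1` gives 25.1%
compound 2 `O=C(CCCCC1CCSS1)Nc1ccc(Cl)cn1` gives 74.5%

Compound 2 holds the higher of the two numbers. Compound 3 `O=C(CCCCC1CCSS1)Nc1ccc(Br)cn1` differs from compound 2 by bromo in place of chloro on an aromatic carbon. It carries bromo in place of chloro on an aromatic carbon. Going by the values given here, the only measured step that bears on this is a number 49.4 percentage points higher from compound 1 to compound 2 (beyond the scatter) with chloro in place of hydrogen on an aromatic carbon. That step shows that this place matters, but it compares no two halogens, so no step beyond the scatter is expected in this assay here. The expected change is a number 2.5 percentage points lower from compound 2 to compound 3 (within the scatter) in this read-out. For compound 3 the estimate is 72% within a range of 55% to 88% in this assay for now.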

Compound 3, percent growth inhibition at one concentration: 42.3%
The estimate for compound 3 lay 29.7 percentage points above the measured number; the whole stated range lies above it.
By their numbers in this assay, from the lowest: compound 1; then compound 3; then compound 2.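

In this assay the identity of the halogen matters on this aromatic carbon: bromo in place of chloro gives a number 32.2 percentage points lower from compound 2 to compound 3 (beyond the scatter) and the gain seen with chloro does not carry over in full to bromo. Bromo in place of hydrogen still gives a number 17.2 percentage points higher from compound 1 to compound 3 (beyond the scatter) and so the three compounds order as hydrogen, bromo, chloro, from the lowest number. Nothing at hand explains the difference between the two halogens. Open, on these data alone, is how fluoro, iodo, methoxy or an amine would read at this place. Also open, as far as these compounds go, is whether this order would hold at other concentrations.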